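The compounds below may be only part of what the source reports. "The series", "measured", "known", "first", "only" and "open" are said of these compounds alone.

Compounds measured so far:
- Compound 1, `COc1ccc(CNc2nc([SeH])nc3ccccc23)cc1`: 71600 nM
- Compound 2, `CSc1ccc(CNc2nc([SeH])nc3ccccc23)cc1`: 42900 nM
- Compound 3, `[SeH]c1nc(NCc2ccccc2)c2ccccc2n1`: 62200 nM

All three share one core and differ only in the group on the outer benzene ring. In a functional assay on HT-29 cells (Homo sapiens) for cytotoxicity, read by MTT assay, with a stated time of 72 h (on this read-out higher numbers stand for weaker inhibition of growth and lower numbers for stronger inhibition of growth), compound 1 gives 71600 nM, the highest of the three numbers, but its nearest neighbour compound 3 sits only a 1.2-fold lower number from compound 1 to compound 3 (0.06 log units; within the scatter) away and compound 2 only a 1.7-fold lower number from compound 1 to compound 2 (0.22 log units; within the scatter) away, so the three compounds cannot be told apart on these numbers.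

Compound 4, `COc1ccc(CNc2nc(SC)nc3ccccc23)cc1`, is not yet measured. It differs from compound 1 at a different place: a group of 2 heavy atoms (1 carbon, 1 sulfur; no ring) in place of one selenium atom, on an aromatic carbon. Within the data shown here, none of the measured steps touches this part of the molecule; they all concern the outer benzene ring (a 1.7-fold lower number from compound 1 to compound 2 (0.22 log units; within the scatter), a 1.2-fold lower number from compound 1 to compound 3 (0.06 log units; within the scatter), a 1.4-fold higher number from compound 2 to compound 3 (0.16 log units; within the scatter)), and each stayed within the scatter. There is therefore no direct guide for this change, and the expectation can only be anchored on compound 1 with a wide range. Compound 4 is expected to give about 90000 nM in this assay, between 30000 nM and 300000 nM, which would be a step of a 1.3-fold higher number from compound 1 to compound 4 (0.10 log units; within the scatter).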

Compound 4, concentration for 50% growth inhibition: 70200 nM
The estimate for compound 4 lay 1.3-fold (0.11 log units) above the measured number; low and high end bracket the measured number.
By their numbers in this assay, from the lowest: compounds 2, 3, 4 and 1 (each within the scatter of the next).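

In this assay, placing methylsulfanyl in place of the selenium atom, on the aromatic carbon between two ring nitrogen atoms, gives a 1.0-fold lower number from compound 1 to compound 4 (0.01 log units; within the scatter). Among these compounds, the earlier steps all concerned the outer benzene ring, so this is the first reading at this position, and it shows that the selenium atom and methylsulfanyl cannot be told apart here, at least with methoxy on the outer ring. The data shown offer no measurement that could explain this result.

On these data alone, it remains open whether another group at this position, such as an amine or a longer chain like butylsulfanyl, would give a number beyond the scatter. As far as these compounds go, it is also open whether methylsulfanyl at this position would match the selenium atom on the outer-ring patterns of compound 2 and compound 3.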